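This account rests on a few compounds, and the source may have more. Where it says the series, first, only, none or still open, it means among the compounds named here.

Compound 1 `O=C(Nc1cccc(-c2oc3cc(-c4ccc(F)cc4)ccc3c(=O)c2O)c1)c1ccc(F)cc1` gives 14200 nM in a functional assay on HCC1937 cells (Homo sapiens) for antiproliferative activity, read by CCK-8 assay, with a stated time of 72 h; a lower number here means a stronger inhibitor, a higher number a weaker inhibitor. Compound 2 `Cc1ccc(C(=O)Nc2cccc(-c3oc4cc(-c5ccc(F)cc5)ccc4c(=O)c3O)c2)cc1` gives 7110 nM in this assay, and compound 3 `O=C(Nc1cccc(-c2oc3cc(-c4ccc(F)cc4)ccc3c(=O)c2O)c1)c1ccc(C(F)(F)F)cc1` gives 7350 nM. On these three numbers compound 3 sits between the other two, with a 1.0-fold higher number from compound 2 to compound 3 (0.01 log units; within the scatter) and a 1.9-fold lower number from compound 1 to compound 3 (0.29 log units; within the scatter) both within the scatter, as is a 2.0-fold lower number from compound 1 to compound 2 (0.30 log units; within the scatter). Compound 4 `O=C(Nc1cccc(-c2oc3cc(-c4ccc(F)cc4)ccc3c(=O)c2O)c1)c1cc(F)cc(F)c1` differs from compound 3 by 3,5-difluorophenyl in place of 4-(trifluoromethyl)phenyl on a carbonyl carbon. Among the measured compounds shown here, the steps that bear on it are the earlier swaps on the same benzamide ring, a 1.9-fold lower number from compound 1 to compound 3 (0.29 log units; within the scatter) and a 1.0-fold higher number from compound 2 to compound 3 (0.01 log units; within the scatter), neither of which moved the number beyond the scatter. A move of similar size is therefore expected here, with no clear direction, so a 1.1-fold higher number from compound 3 to compound 4 (0.04 log units; within the scatter) is the estimated step. For compound 4 the expected value in this assay is 8000 nM, with a range of 3500 nM to 18000 nM.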

Compound 4, half-maximal inhibitory concentration: 2070 nM
For compound 4 the middle estimate is 3.9-fold (0.59 log units) above the measured one; the whole stated range lies above it.
By their numbers in this assay, from the lowest: compound 4; then compounds 2, 3 and 1 (each within the scatter of the next).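

In this assay, the group on the carbonyl carbon can move the number beyond the scatter: 3,5-difluorophenyl gives a 3.6-fold lower number from compound 3 to compound 4 (0.55 log units; beyond the scatter), a 3.4-fold lower number from compound 2 to compound 4 (0.54 log units; beyond the scatter) and a 6.9-fold lower number from compound 1 to compound 4 (0.84 log units; beyond the scatter), whereas exchanges among the three 4-substituted phenyl groups stayed within it. Compound 4 is therefore the most potent of the four in this assay. No measurement at hand accounts for this difference. Still open, from the compounds shown here alone, is whether 3-fluorophenyl alone would match compound 4, and how an amine or a carboxylic acid on this phenyl ring would read.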